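Changing the aryl group of compound 2

The source may report more compounds than this note shows. Statements on the series, on what has been measured and on what is new or still open speak of the compounds shown alone.

Compound 1 `Cc1cc(=O)c2c(O)cc(OCc3ccccc3)c([C@H]3CCN(C)C[C@H]3O)c2o1`: 1%
Compound 2 `Cc1oc2c([C@H]3CCN(C)C[C@H]3O)c(O)cc(O)c2c(=O)c1C(O)c1ccc(F)c(Br)c1`: 14%

Both values come from a functional assay on MCF7 cells (Homo sapiens) for inhibition, read by MTT assay, with a stated time of 48 h, tested at 10 uM; a higher number here means more inhibition of growth at the concentration tested, a lower number less inhibition of growth. Compound 2 stands highest of the two, and its gap to compound 1 lies beyond the usual scatter, yet neither compound stops much growth at the concentration tested.

Compound 3 `CCOc1ccc(Br)c(C(O)c2c(C)oc3c([C@H]4CCN(C)C[C@H]4O)c(O)cc(O)c3c2=O)c1` has not been measured. It keeps the shared core of compound 2 but carries 2-bromo-5-ethoxyphenyl in place of 3-bromo-4-fluorophenyl on a saturated chain carbon bound to an aromatic carbon and an oxygen on a saturated carbon.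

Within the data shown here, no measured pair shows what changing this group does, so the expectation is uncertain. In this assay, the expected step is a number 3 percentage points lower from compound 2 to compound 3 (within the scatter), which is no change beyond the scatter. The estimate for compound 3 is 11%, with an expected range of 0% to 28%.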

Compound 3, percent growth inhibition at one concentration: 9%
Compound 3: middle estimate off by 2 percentage points, on the high side; the measured number falls inside the stated range.
By their numbers in this assay, from the lowest: compounds 1, 3 and 2 (each within the scatter of the next, the first and the last beyond it).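

In this assay, replacing 3-bromo-4-fluorophenyl with 2-bromo-5-ethoxyphenyl gives a number 5 percentage points lower from compound 2 to compound 3 (within the scatter) and thus no change beyond the scatter, so this aryl group on the saturated chain carbon can carry a different substitution and two more heavy atoms with no clear effect on the read-out. Among these compounds, this pair gives the first direct reading of the position, as compound 1 and compound 2 differ in more than one place. No supporting measurement is available to explain this result.

On these data alone, the swap alters several features of the aryl ring at once, and what each contributes remains unknown. As far as these compounds go, it also remains open whether an amine or a carboxylic acid on this ring would shift growth inhibition beyond the scatter.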